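Aryl-piperazine series: ortho substituent on the aryl ring

The source may report more compounds than this note shows. Statements on the series, on what has been measured and on what is new or still open speak of the compounds shown alone.

Measured so far in a functional assay on aorta for antagonist activity at Alpha-1D adrenergic receptor (Rattus norvegicus); a lower number here means tighter binding, a higher number weaker binding:
compound 1 `CN(C)C(=O)c1cccnc1NCCCN1CCN(c2ccccc2C#N)CC1` — 10 nM
compound 2 `CN(C)C(=O)c1cccnc1NCCCN1CCN(c2ccccc2O)CC1` — 63.1 nM
compound 3 `CN(C)C(=O)c1cccnc1NCCCN1CCN(c2ccccc2-c2ccccc2)CC1` — 63.1 nM

Compound 3 stands level with compound 2 at the digits shown; no change at the digits printed from compound 2 to compound 3 (within the scatter). Both sit at the high end of the three numbers, and compound 1 gives the lowest: a 6.3-fold higher number from compound 1 to compound 3 (0.80 log units; beyond the scatter), matching a 6.3-fold higher number from compound 1 to compound 2 (0.80 log units; beyond the scatter).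

Compound 4 `CN(C)C(=O)c1cccnc1NCCCN1CCN(c2ccccc2Cc2ccccc2)CC1` carries the change (benzyl in place of phenyl on an aromatic carbon). Within the data shown here, no measured step changes a phenyl into a benzyl; the nearest reference is the hydroxy-to-phenyl exchange, which moved nothing beyond the scatter, while only the loss of the cyano gave a clear step. The step to compound 4 is therefore expected to be small, a 1.3-fold higher number from compound 3 to compound 4 (0.10 log units; within the scatter), with the weaker direction slightly favoured.

Compound 4 is estimated at 80 nM, expected range 30 nM to 250 nM.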

Compound 4, dissociation constant: 79.4 nM
Estimate against measurement, compound 4: 1.0-fold (0.00 log units) above, within the range that was stated.
By their numbers in this assay, from the lowest: compound 1; then compounds 2, 3 and 4 (each within the scatter of the next).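

Benzyl in place of phenyl on this aromatic carbon leaves the number within the scatter (a 1.3-fold higher number from compound 3 to compound 4 (0.10 log units; within the scatter)), and the same holds for benzyl in place of hydroxy (a 1.3-fold higher number from compound 2 to compound 4 (0.10 log units; within the scatter)). Benzyl in place of cyano gives a step beyond the scatter (a 7.9-fold higher number from compound 1 to compound 4 (0.90 log units; beyond the scatter)), so among these four groups only the cyano of compound 1 stands apart, while hydroxy, phenyl and benzyl show no order. No evidence on hand explains this pattern.

Open, as far as these compounds go, is whether the lower number is specific to the nitrile or is shared by an amide or a carboxylic acid here. A phenethyl group would show whether a longer chain also stays level with benzyl.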